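Methylsulfonyl for dimethylcarbamoyl on compound 2

This account rests on a few compounds, and the source may have more. Where it says the series, first, only, none or still open, it means among the compounds named here.

In an in vitro ADME assay on microsomes from liver (Homo sapiens) for metabolic stability (a higher number here means faster removal of the compound, a lower number slower removal), compound 2 `CN(C)C(=O)c1cc(Cl)c(NC(=O)N2CCN3C(=O)N([C@H]4C[C@@H]4c4ccccc4)C(=O)[C@@H]3C2)c(Cl)c1` gives 49000 mL.min-1.g-1. That lies within the scatter of both compound 1 `O=C(Nc1cccnc1-c1ccsc1)N1CCN2C(=O)N([C@H]3C[C@@H]3c3ccccc3)C(=O)[C@@H]2C1` at 40000 mL.min-1.g-1 and compound 3 `O=C(Nc1cccnc1-c1cccc(Cl)c1)N1CCN2C(=O)N([C@H]3C[C@@H]3c3ccccc3)C(=O)[C@@H]2C1` at 90000 mL.min-1.g-1.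

Compound 4 `CS(=O)(=O)c1cc(Cl)c(NC(=O)N2CCN3C(=O)N([C@H]4C[C@@H]4c4ccccc4)C(=O)[C@@H]3C2)c(Cl)c1` carries methylsulfonyl in place of dimethylcarbamoyl on an aromatic carbon.

Going by the values given here, the only measured single change is a 2.3-fold higher number from compound 1 to compound 3 (0.35 log units; beyond the scatter), a modest step where 3-chlorophenyl replaces thiophen-3-yl. It involves other groups at another place, so it offers little guidance here. Among the compounds with values here, no measured step covers this exchange, so no step beyond the scatter is expected in this assay.

The estimate means a 1.2-fold lower number from compound 2 to compound 4 (0.09 log units; within the scatter), an expected step within the scatter. Compound 4 is estimated at 40000 mL.min-1.g-1, with an expected range of 16000 mL.min-1.g-1 to 95000 mL.min-1.g-1.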

Compound 4, intrinsic clearance in microsomes: 58000 mL.min-1.g-1
For compound 4 the middle estimate is 1.5-fold (0.16 log units) below the measured one; the measured number falls inside the stated range.
By their numbers in this assay, from the lowest: compounds 1, 2, 4 and 3 (each within the scatter of the next, the first and the last beyond it).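

In this assay, placing methylsulfonyl instead of dimethylcarbamoyl meta to two chloro groups gives a 1.2-fold higher number from compound 2 to compound 4 (0.07 log units; within the scatter) and so leaves the two groups indistinguishable in this test. Going by these compounds alone, this is the first measured step at this position, and it shows that this exchange, which removes the nitrogen and brings in sulfur, produces no change beyond the scatter. Nothing measured here explains why the two groups behave alike. As far as these compounds go, whether an amine or a carboxylic acid at this position would give a clearer shift remains open. So does the contribution of the two chloro groups, which both compounds share.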